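Swapping the amide tail methyl for pyrrolidin-1-yl

This account rests on a few compounds, and the source may have more. Where it says the series, first, only, none or still open, it means among the compounds named here.

Three compounds share one core. Compound 2 `CC/C=C/C(=O)Nc1cc2c(N3CCCc4ccccc43)ncnc2cc1OC` gives 6310 nM in a functional assay on PC-3 cells (Homo sapiens) for antiproliferative activity, read by MTT assay, with a stated time of 72 h (on this read-out higher numbers stand for weaker inhibition and lower numbers for stronger inhibition), the second highest of the three numbers. Compound 1 `C=C(C)C(=O)Nc1cc2c(N3CCc4ccccc43)ncnc2cc1O[C@@H]1CCOC1` gives 4910 nM, within the scatter of compound 2. Within the data shown here, compound 3 `CC/C=C/C(=O)Nc1cc2c(N3CCCc4ccccc43)ncnc2cc1O[C@@H]1CCOC1` gives 14300 nM, and the only measured step, a 2.3-fold higher number from compound 2 to compound 3 (0.36 log units; beyond the scatter), concerns oxolan-3-yl in place of methyl on an oxygen on an aromatic ring. Compound 4 `COc1cc2ncnc(N3CCCc4ccccc43)c2cc1NC(=O)/C=C/CN1CCCC1` differs from compound 2 at another place: pyrrolidin-1-yl in place of methyl on a saturated chain carbon bound to a double-bonded chain carbon. Among the measured compounds shown here, no measured step touches this place, so no direction can be read from the numbers; a step within the scatter is expected, a 1.3-fold lower number from compound 2 to compound 4 (0.10 log units; within the scatter). Compound 4 is therefore estimated at 5000 nM, with a range from 1500 nM to 16000 nM.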

Compound 4, half-maximal inhibitory concentration: 1740 nM
The estimate for compound 4 lay 2.9-fold (0.46 log units) above the measured number; measured number inside the range.
By their numbers in this assay, from the lowest: compound 4; then compounds 1 and 2 (each within the scatter of the next); then compound 3.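

Until now, nothing measured touched the amide tail. In this assay, pyrrolidin-1-yl in place of methyl on a saturated chain carbon bound to a double-bonded chain carbon gives a 3.6-fold lower number from compound 2 to compound 4 (0.56 log units; beyond the scatter) and so this place accepts a larger group holding a ring and a nitrogen, with stronger inhibition. No measurement at hand explains this step.

Dimethylamino or piperidin-1-yl at the same carbon would help show whether the nitrogen or the ring size counts. Also open, going by these compounds, is whether pyrrolidin-1-yl gives a similar step alongside oxolan-3-yl on the oxygen.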